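Swapping the Aryl Ring on a Trimethoxyphenyl Pyrimidine Core

This account rests on a few compounds, and the source may have more. Where it says the series, first, only, none or still open, it means among the compounds named here.

Compound 1: `COc1cc(-c2cc(-c3ccc(Br)cc3)nc(-c3ccccc3)n2)cc(OC)c1OC` gives 4320 nM in a functional assay on HCT-116 cells (Homo sapiens) for inhibition, read by MTT assay, with a stated time of 48 h; on this read-out higher numbers stand for weaker inhibition and lower numbers for stronger inhibition.
Compound 2: `COc1cc(-c2cc(-c3ccc(C)cc3)nc(-c3ccccc3)n2)cc(OC)c1OC` gives 15700 nM in this assay.

Among these two numbers compound 2 stands highest, the only measured step being a 3.6-fold higher number from compound 1 to compound 2 (0.56 log units; beyond the scatter). Compound 3 is `COc1cc(-c2cc(-c3cccs3)nc(-c3ccccc3)n2)cc(OC)c1OC`; the change from compound 2 is thiophen-2-yl in place of 4-methylphenyl on an aromatic carbon. Among the compounds with values here, no measured step exchanges a whole ring, so the one known step offers no direct guide, only a sign that this position tolerates small changes. For compound 3 the expectation is a number somewhat lower than compound 2, a 2.6-fold lower number from compound 2 to compound 3 (0.42 log units; beyond the scatter), an estimate of 6000 nM within 2000 nM to 20000 nM.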

Compound 3, half-maximal inhibitory concentration: 17000 nM
For compound 3 the middle estimate is 2.8-fold (0.45 log units) below the measured one; the range from low to high includes it.
By their numbers in this assay, from the lowest: compound 1; then compounds 2 and 3 (each within the scatter of the next).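

In this assay, replacing a six-membered ring with a five-membered, sulfur-containing one makes no clear difference here, with a 1.1-fold higher number from compound 2 to compound 3 (0.03 log units; within the scatter). The 4-bromophenyl group also stands apart from thiophen-2-yl, with a 3.9-fold higher number from compound 1 to compound 3 (0.59 log units; beyond the scatter), so among these three groups only 4-bromophenyl gives a clearly lower number. Nothing available explains this pattern. The compounds shown leave open whether another halogen, such as chloro or fluoro on the same phenyl ring, would match bromo. They also leave open how a pyridine ring, or a phenyl ring carrying an amine or a carboxylic acid, would read at this position.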